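A few compounds are considered here, and "the series" means these few. Any claim that something is new, unique, unknown or untested is made for them only; others in the source may bear on it.

Compound 1 `CCN1CCN(c2cc(C)c3cc(NC(=O)c4cccc(C)c4)ccc3n2)CC1` gives 13700 nM in a functional assay on SK-BR-3 cells (Homo sapiens) for antiproliferative activity, read by MTT assay, with a stated time of 72 h; on this read-out lower numbers stand for stronger inhibition and higher numbers for weaker inhibition.
Compound 2 `Cc1cc(NCCN2CCN(C)CC2)nc2ccc(NC(=O)c3ccc(Cl)c(Cl)c3)cc12` gives 2690 nM in this assay.
Compound 3 `Cc1cc(N2CCN(C)CC2)nc2ccc(NC(=O)c3ccc(Cl)c(Cl)c3)cc12` gives 6320 nM in this assay.

Among the three measured compounds, compound 1 stands highest, with compound 3 nearest and compound 2 furthest below it. For the measured compounds named here, the only single-place step measured concerns the other end of the shared core: a 2.3-fold higher number from compound 2 to compound 3 (0.37 log units; beyond the scatter). That step says nothing about the aryl group of the amide, which is where compound 4 `CCc1ccc(C(=O)Nc2ccc3nc(N4CCN(CC)CC4)cc(C)c3c2)cc1` departs from compound 1. The change is 4-ethylphenyl in place of 3-methylphenyl on a carbonyl carbon. Going by the values given here, no measured pair isolates a change on the amide aryl group; compounds 1 and 3 differ there, but they also differ on the piperazine, so only their two values can be compared, and they show compound 3 lower than compound 1. On this basis the direction of the step is not settled, and no step beyond the scatter is expected in this assay, though a small shift toward stronger inhibition cannot be excluded. Compound 4 is therefore estimated at 10000 nM, within a range from 3500 nM to 30000 nM. This estimate corresponds to an expected step of a 1.4-fold lower number from compound 1 to compound 4 (0.14 log units; within the scatter).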

Compound 4, half-maximal inhibitory concentration: 9850 nM
Estimate against measurement, compound 4: 1.0-fold (0.01 log units) above; the range from low to high includes it.
By their numbers in this assay, from the lowest: compound 2; then compounds 3, 4 and 1 (each within the scatter of the next, the first and the last beyond it).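

In this assay, for the compounds shown here, the step of a 1.4-fold lower number from compound 1 to compound 4 (0.14 log units; within the scatter) is the first measured change that isolates the aryl group of the amide, on a carbonyl carbon whose other neighbour is an amide-type nitrogen. It shows that, with the rest of the molecule held constant, replacing 3-methylphenyl with 4-ethylphenyl does not move the number beyond the scatter, although the alkyl group and its place on the ring both differ between the two groups. No independent measurement bears on this result, so it stands here without an explanation.

Since both features change in this one step, the compounds shown cannot separate the contribution of the alkyl group from that of its place on the ring, and 4-methylphenyl or 3-ethylphenyl would be needed to do so. They also leave open whether this position would stay as unresponsive with a group of another kind on the phenyl ring, such as an amine or a carboxylic acid in place of the ethyl group.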